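Furan-3-yl Replaces 3-Nitrophenyl on the Piperazine Arm

The compounds below may be only part of what the source reports. "The series", "measured", "known", "first", "only" and "open" are said of these compounds alone.

Compound 1 `O=C1O[C@@H](Cn2ccnn2)CN1c1ccc(N2CCN(Cc3ccc([N+](=O)[O-])o3)CC2)c(F)c1`: 139000 ng.h/mL
Compound 2 `O=C1O[C@@H](Cn2ccnn2)CN1c1ccc(N2CCN(Cc3cccc([N+](=O)[O-])c3)CC2)c(F)c1`: 74500 ng.h/mL

Of the compounds shown here, two have been measured in an ADME assay on the whole organism (plasma, strain Sprague-Dawley) for pharmacokinetics, with Rattus norvegicus as the target, at a dose of 50 mg/kg by the oral route; on this read-out higher numbers stand for higher exposure at the dose given and lower numbers for lower exposure. Compound 1 gives 139000 ng.h/mL and compound 2 gives 74500 ng.h/mL. The step between them, a 1.9-fold lower number from compound 1 to compound 2 (0.27 log units; within the scatter), is the only one available, and since it lies within the scatter the two compounds cannot be told apart on these numbers; compound 2 simply stands beside compound 1.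

Compound 3 `O=C1O[C@@H](Cn2ccnn2)CN1c1ccc(N2CCN(Cc3ccoc3)CC2)c(F)c1` differs from compound 2 by furan-3-yl in place of 3-nitrophenyl on a saturated chain carbon bound to an amine nitrogen in a ring. Among the compounds with values here, the only measured step that bears on this position, a 1.9-fold lower number from compound 1 to compound 2 (0.27 log units; within the scatter), exchanged one aryl group for another at the same place without moving the read-out beyond the scatter. On that basis no change beyond the scatter is expected in this assay, though the removal of the nitro group leaves the direction open. Compound 3 is therefore estimated at 80000 ng.h/mL, within 35000 ng.h/mL to 180000 ng.h/mL, an expected step of a 1.1-fold higher number from compound 2 to compound 3 (0.03 log units; within the scatter).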

Compound 3, area under the concentration-time curve: 85800 ng.h/mL
Compound 3: the middle estimate sits 1.1-fold (0.03 log units) below what was measured; the measured number falls inside the stated range.
By their numbers in this assay, from the lowest: compounds 2, 3 and 1 (each within the scatter of the next).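

Within the data shown here, with compound 3, the place on a saturated chain carbon bound to an amine nitrogen in a ring carries a group without a nitro group for the first time, and in this assay the steps read a 1.2-fold higher number from compound 2 to compound 3 (0.06 log units; within the scatter) and a 1.6-fold lower number from compound 1 to compound 3 (0.21 log units; within the scatter). Neither losing the nitro group nor going from the 9 heavy atoms of 3-nitrophenyl to the 5 of furan-3-yl carries the read-out beyond the scatter, so all three compounds stand together on these numbers. Nothing at hand speaks to why the read-out holds across these groups.

On these data alone, all three compounds carry an aromatic ring at this place, so it stays open whether a saturated amine, a carboxylic acid or a longer chain would hold the read-out. Also open, as far as these compounds go, is whether unsubstituted furan-2-yl would stand with them.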